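Methyl to chloro on the aryl ring of compound 1

The compounds below may be only part of what the source reports. "The series", "measured", "known", "first", "only" and "open" are said of these compounds alone.

Measured in a functional assay on the whole organism (strain Wistar) for inhibition, with Rattus norvegicus as the target, read by paw edema, with stated times of 30 min and 3 h, at a dose of 0.05 mmol/kg by the oral route; a higher number here means more inhibition at the dose given (going by the name of the read-out), a lower number less inhibition:
compound 1, `Cc1ccc(C2=NN(c3ccc(S(C)(=O)=O)cc3)C(=O)CC2)cc1`: 46.7%
compound 2, `CS(=O)(=O)c1ccc(N2N=C(c3ccc(Br)cc3)CCC2=O)cc1`: 10%

Within the data shown here, compound 1 stands highest of the two numbers; compound 2 is the nearest and lies below it, the only measured step being a number 36.7 percentage points lower from compound 1 to compound 2 (beyond the scatter), bromo in place of methyl on an aromatic carbon. Compound 3, `CS(=O)(=O)c1ccc(N2N=C(c3ccc(Cl)cc3)CCC2=O)cc1`, differs from compound 1 by chloro in place of methyl on an aromatic carbon. The bromo step bears directly on this change, as a halogen again replaces the methyl on that aromatic carbon, and that step was large. A downward step in this assay is therefore expected, estimated at a number 26.7 percentage points lower from compound 1 to compound 3 (beyond the scatter). For compound 3 the expected value is 20%, within 5% to 40%.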

Compound 3, a percentage reported as inhibition, in the whole organism at one dose (the size of the read-out at that dose, not a potency): 26.6%
For compound 3 the middle estimate is 6.6 percentage points below the measured one, and the stated range covers the measured number.
By their numbers in this assay, from the lowest: compound 2; then compound 3; then compound 1.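

In this assay, the change from 4-methylphenyl to 4-chlorophenyl also lowers inhibition (a number 20.1 percentage points lower from compound 1 to compound 3 (beyond the scatter)), so the loss seen with bromo extends to a second halogen at this position. The two halogens also differ from each other (a number 16.6 percentage points higher from compound 2 to compound 3 (beyond the scatter)), so the outcome here depends on which halogen replaces methyl, not merely on methyl being replaced. Nothing available here bears on the reason for either step.

Fluoro at this position remains open, as it could show whether the order among the halogens continues. Whether a methoxy group, an amine or a carboxylic acid here could match or exceed the methyl compound also remains unresolved.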